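This account rests on a few compounds, and the source may have more. Where it says the series, first, only, none or still open, it means among the compounds named here.

The measured compounds in a functional assay on MDA-MB-231 cells (Homo sapiens) for cytotoxicity, read by sulforhodamine B assay, with a stated time of 48 h; on this read-out lower numbers stand for stronger inhibition of growth and higher numbers for weaker inhibition of growth:

compound 1, `Cc1ccc(-c2ccc(C)n2-c2ccc(-c3nc4ccccc4s3)cc2)cc1`, gives 4400 nM;
compound 2, `Cc1ccc(-c2ccc(F)cc2)n1-c1ccc(-c2nc3ccccc3s2)cc1`, gives 4340 nM;
compound 3, `COc1ccc2nc(-c3ccc(-n4c(C)ccc4-c4ccc(C)cc4)cc3)sc2c1`, gives 4010 nM.

Compound 2 differs from compound 1 by one change, (fluoro in place of methyl on an aromatic carbon), and this change produced a 1.0-fold lower number from compound 1 to compound 2 (0.01 log units; within the scatter). Compound 3 differs from compound 1 only in the core: methoxy in place of hydrogen on an aromatic carbon, which gave a 1.1-fold lower number from compound 1 to compound 3 (0.04 log units; within the scatter). Compound 4, `COc1ccc2nc(-c3ccc(-n4c(C)ccc4-c4ccc(F)cc4)cc3)sc2c1`, carries the same change on the core of compound 3, namely (fluoro in place of methyl on an aromatic carbon), with the same surroundings at the place of change. Since the earlier step of a 1.0-fold lower number from compound 1 to compound 2 (0.01 log units; within the scatter) lay within the scatter, compound 4 is expected to show a step of about the same size, a 1.0-fold lower number from compound 3 to compound 4 (0.00 log units; within the scatter). Compound 4 is therefore estimated to give 4000 nM in this assay, with a range from 2000 nM to 8000 nM.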

Compound 4, concentration for 50% growth inhibition: 4060 nM
Estimate against measurement, compound 4: 1.0-fold (0.01 log units) below, and the stated range covers the measured number.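

In this assay, putting 4-fluorophenyl in place of 4-methylphenyl on the methoxy-bearing core gave a 1.0-fold higher number from compound 3 to compound 4 (0.01 log units; within the scatter), which agrees with the earlier step on the core of compound 1: the same change on two cores in this assay, a 1.0-fold lower number (0.01 log units; within the scatter) from compound 1 to compound 2 and a 1.0-fold higher number (0.01 log units; within the scatter) from compound 3 to compound 4, 1.0-fold (0.01 log units) apart, within the scatter of two such steps. Methoxy in place of hydrogen, read on the fluoro pair, gave a 1.1-fold lower number from compound 2 to compound 4 (0.03 log units; within the scatter), which agrees with its earlier step as well: the same change on two cores in this assay, a 1.1-fold lower number (0.04 log units; within the scatter) from compound 1 to compound 3 and a 1.1-fold lower number (0.03 log units; within the scatter) from compound 2 to compound 4, 1.0-fold (0.01 log units) apart, within the scatter of two such steps. Each change thus left the number within the scatter on both cores, but with steps this small the series does not show whether a step of clear size would carry from one core to another.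

The compounds shown leave open what an amine, a carboxylic acid or a longer chain would do in place of the fluoro or methyl group. They also leave open how a group other than methoxy, such as a nitrile, would behave on the core.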